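Antiproliferative series: working notes ahead of compound 3

This account rests on a few compounds, and the source may have more. Where it says the series, first, only, none or still open, it means among the compounds named here.

Measured so far in a functional assay on OVCAR-4 cells (Homo sapiens) for antiproliferative activity, with a stated time of 48 h; a lower number here means a stronger inhibitor of growth, a higher number a weaker inhibitor of growth:
compound 1 `Cc1cc(O)c(C2=NN(c3ccc(S(N)(=O)=O)cc3)C(c3ccccc3O)C2)cc1Cl` gives 16000 nM
compound 2 `Cc1cc(O)c(C2=NN(c3ccc(S(N)(=O)=O)cc3)C(c3ccccc3Cl)C2)cc1Cl` gives 8480 nM

Compound 2 holds the lower of the two numbers shown, but the only step between them, a 1.9-fold lower number from compound 1 to compound 2 (0.28 log units; within the scatter), lies within the scatter, so no ordering of the two compounds is claimed.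

Compound 3 `Cc1cc(O)c(C2=NN(c3ccc(S(N)(=O)=O)cc3)C(/C=C/c3ccccc3)C2)cc1Cl` differs from compound 2 in one place: 2-phenylethenyl in place of 2-chlorophenyl on a saturated ring carbon. The group that leaves and the group that enters are each without donors or acceptors, and the group that enters brings one double bond outside aromatic rings.

Among the compounds with values here, no measured step bears on this exchange. Within the data shown here, the single step available, from compound 1 to compound 2, concerns a different group and is itself within the scatter, so it gives no direction for the present change. With nothing in the data pointing either way, the expectation for this assay is a step of no size beyond the scatter from compound 2 to compound 3, set as a 1.1-fold higher number from compound 2 to compound 3 (0.03 log units; within the scatter).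

Compound 3 is therefore estimated at 9000 nM, with a range from 3000 nM to 30000 nM.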

Compound 3, concentration for total growth inhibition: 18900 nM
For compound 3 the middle estimate is 2.1-fold (0.32 log units) below the measured one; measured number inside the range.
By their numbers in this assay, from the lowest: compounds 2, 1 and 3 (each within the scatter of the next, the first and the last beyond it).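

In this assay, within the data shown here, the saturated ring carbon next to the ring nitrogen gives the first step that lies beyond the scatter (a modest one): a 2.2-fold higher number from compound 2 to compound 3 (0.35 log units; beyond the scatter) when 2-phenylethenyl replaces 2-chlorophenyl. Among these compounds, the other exchange at this carbon, a 1.2-fold higher number from compound 1 to compound 3 (0.07 log units; within the scatter), stays within the scatter, so 2-phenylethenyl and 2-hydroxyphenyl are not told apart here, and the only separation among the three compounds is the one between compound 2 and compound 3. Nothing in the available data gives a reason for that step.

Going by these compounds, the three groups compared on this carbon each hold a six-membered aromatic ring of carbon only, so the response to a group without such a ring, such as a longer saturated chain, an amine or a carboxylic acid, remains open. On these data alone, it also remains open whether the step from 2-chlorophenyl to 2-phenylethenyl would keep its direction and size with a different group in place of the 5-chloro-2-hydroxy-4-methylphenyl or the 4-sulfamoylphenyl group on the shared core.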